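Ring substituent swap on a sulfonamide benzoic acid series

A few compounds are considered here, and "the series" means these few. Any claim that something is new, unique, unknown or untested is made for them only; others in the source may bear on it.

Measured so far:
compound 1, `CCCCCCCCS(=O)(=O)Nc1ccc(-c2ccc(OC)cc2)cc1C(=O)O`, 19500 nM
compound 2, `CCCCCCCCS(=O)(=O)Nc1ccc(-c2ccccc2F)cc1C(=O)O`, 34600 nM
compound 3, `CCCCCCCCS(=O)(=O)Nc1ccc(-c2cccc(F)c2)cc1C(=O)O`, 37600 nM

All three compounds share the same core and differ only in the distal aromatic ring, and in an assay on mitochondria (strain BALB/c) for inhibition of glycerol-3-phosphate acyltransferase 1, mitochondrial (Mus musculus), read by scintillation counting, with a stated time of 10 min (a higher number here means a weaker inhibitor, a lower number a stronger inhibitor), their numbers lie close together. Compound 3 sits at the high end of the three values, yet neither gap sets it apart: a 1.1-fold higher number from compound 2 to compound 3 (0.04 log units; within the scatter) and a 1.9-fold higher number from compound 1 to compound 3 (0.29 log units; within the scatter). The third comparison, a 1.8-fold higher number from compound 1 to compound 2 (0.25 log units; within the scatter), tells the same story.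

Compound 4, `CCCCCCCCS(=O)(=O)Nc1ccc(-c2ccccc2O)cc1C(=O)O`, has not been measured. The change from compound 3 is 2-hydroxyphenyl in place of 3-fluorophenyl on an aromatic carbon. Within the data shown here, two measured steps bear on it. Both also exchange one small substituent on the distal ring for another: a 1.1-fold higher number from compound 2 to compound 3 (0.04 log units; within the scatter) moves a fluorine between ring positions, and a 1.9-fold higher number from compound 1 to compound 3 (0.29 log units; within the scatter) exchanges a methoxy group for a fluorine. Neither moved the number beyond the scatter. Among the measured compounds shown here, the hydroxy group brings a hydrogen-bond donor that no measured compound carries, so this step is less well covered, but the evidence points to little movement either way. The expected step is therefore small, a 1.3-fold lower number from compound 3 to compound 4 (0.10 log units; within the scatter), and compound 4 is estimated at 30000 nM, in a range from 10000 nM to 90000 nM.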

Compound 4, half-maximal inhibitory concentration: 61700 nM
Beside the measured number, compound 4's estimate is 2.1-fold (0.31 log units) below it; the measured number falls inside the stated range.
By their numbers in this assay, from the lowest: compounds 1, 2, 3 and 4 (each within the scatter of the next, the first and the last beyond it).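

Swapping the fluorine of compound 2 directly for a hydroxy group, the one change here that keeps the substituent in the same place, gives a 1.8-fold higher number from compound 2 to compound 4 (0.25 log units; within the scatter), and the move from the 3-fluorophenyl group gives a 1.6-fold higher number from compound 3 to compound 4 (0.22 log units; within the scatter), so in this assay a hydrogen-bond donor on this ring produces no shift that can be told from the scatter against either fluorinated compound. Among these compounds, the new compound does, however, provide the first step to clear the scatter: 2-hydroxyphenyl in place of 4-methoxyphenyl gives a 3.2-fold higher number from compound 1 to compound 4 (0.50 log units; beyond the scatter), a modest loss of inhibition. Nothing available explains this difference between the 2-hydroxyphenyl and 4-methoxyphenyl compounds.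

The compounds shown leave open whether an amine or a carboxylic acid on the distal ring would behave like the hydroxy group or move the number further. Among the compounds shown here, they also cannot say whether a longer chain on the shared core would matter more than any of these ring changes, since all four compounds carry the same chain and every value so far comes from changes to the distal ring alone.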